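This account rests on a few compounds, and the source may have more. Where it says the series, first, only, none or still open, it means among the compounds named here.

Among the measured compounds shown here, compound 2 `Cc1cccc(NC(=O)c2ccc(Oc3ccccc3)cc2)n1` is the only member of this small set with a number rather than a limit in an in vitro assay on HEK-293T cells for displacement of a labelled ligand from metabotropic glutamate receptor 5 (Homo sapiens), read by scintillation counting (on this read-out higher numbers stand for weaker inhibition and lower numbers for stronger inhibition), where compound 2 gives 7290 nM. Its neighbour compound 1 `Cc1cccc(NC(=O)c2ccc(Br)cc2)n1` carries bromo where compound 2 carries phenoxy. In this assay compound 1 gives > 10000 nM, which is a limit of the assay and not a number. The step of an at least 1.3-fold lower number from compound 1 to compound 2 (0.13 log units; that floor lies within the scatter) can therefore only be stated as a floor, and that floor lies within the scatter, as the limit line the limit of > 10000 nM in this assay, at which 1 of the 2 values shown sits, makes plain. Compound 3 `Cc1cccc(NC(=O)c2ccc(OC(=O)c3ccccc3)cc2)n1` alters the phenoxy group itself: benzoyl in place of phenyl on an oxygen on an aromatic ring. For the measured compounds named here, the single measured step, from compound 1 to compound 2, swapped bromo for phenoxy and showed no clear movement, and no measured step touches the change of phenyl to benzoyl on that oxygen. The expected step of a 1.1-fold higher number from compound 2 to compound 3 (0.04 log units; within the scatter) is accordingly no movement beyond the scatter. Compound 3 is estimated at 8000 nM. For compound 3 the expected range runs from 3000 nM to 20000 nM, and a limit instead of a number remains a real possibility.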

Compound 3, inhibition constant: > 10000 nM
Compound 3 was reported as a limit (the forecaster's own chance of this, stated with the estimate: 35%); middle value at least 1.2-fold (0.09 log units) away from the limit.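

Among the compounds shown here, compound 3 is the first look at a change further out on the phenoxy group: the earlier step replaced the whole group on the aromatic carbon, whereas here the oxygen stays and benzoyl, with its carbonyl, takes the place of phenyl. The result can be read only as an at least 1.3-fold higher number from compound 2 to compound 3 (0.13 log units; that floor lies within the scatter), so it cannot tell whether this change weakens inhibition or leaves it as it was. It does show that adding a carbonyl on this oxygen gives no number in this series, and compound 2 remains the only compound with a measured value, while most of the set now rests on a limit: the limit of > 10000 nM in this assay, at which 2 of the 3 values shown sit.

Going by these compounds, how far compound 3 really lies from compound 2 stays unknown, since only a measured value for compound 3 could settle the size of this step. Also open, on these data alone, is whether a different group on that oxygen, such as a benzyl group or a small acetyl group, or an amine or a carboxylic acid on the outer phenyl ring, would give a number clearly lower than that of compound 2.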